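The source may report more compounds than this note shows. Statements on the series, on what has been measured and on what is new or still open speak of the compounds shown alone.

Measured in a functional assay on HepG2 cells (Homo sapiens) for inhibition, read by MTT assay, with a stated time of 72 h; on this read-out higher numbers stand for weaker inhibition and lower numbers for stronger inhibition:

compound 1 `Cn1ccc2c(Oc3ccc(NC(=O)c4cn(-c5ccc(Cl)cc5)c5ccccc5c4=O)cc3F)ccnc21` gives 290 nM
compound 2 `O=C(Nc1ccc(Oc2ccnc3[nH]ccc23)c(F)c1)c1cn(-c2ccccc2)c2ccccc2c1=O` gives 760 nM
compound 3 `O=C(Nc1ccc(Oc2ccnc3[nH]ccc23)c(F)c1)c1cn(-c2ccc(F)cc2)c2ccccc2c1=O` gives 270 nM

Compound 3 carries the lowest number of the three, but compound 1 sits within the usual scatter of it, so the two cannot be ordered; only compound 2 stands clearly apart, as the step of a 2.8-fold lower number from compound 2 to compound 3 (0.45 log units; beyond the scatter) shows.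

Compound 4 `O=C(Nc1ccc(Oc2ccnc3[nH]ccc23)c(F)c1)c1cn(-c2ccc(Cl)cc2)c2ccccc2c1=O` has not been measured in this assay . It differs from compound 3 by chloro in place of fluoro on an aromatic carbon.

Among the compounds with values here, no measured step covers a chloro in place of a fluoro directly. Within the data shown here, the only measured step on this phenyl ring is the step from compound 2 to compound 3, which is a 2.8-fold lower number from compound 2 to compound 3 (0.45 log units; beyond the scatter) and shows that a halogen at this place is tolerated. Among the measured compounds shown here, compound 1 carries the chloro at the same place but also differs from compound 3 at the core nitrogen, so no single step connects them; their two values, compound 1 at 290 nM and compound 3 at 270 nM, lie within the scatter of each other. Taken together these give no reason to expect a step beyond the scatter, and the estimated step of no change at the digits printed from compound 3 to compound 4 (within the scatter) is accordingly small. Compound 4 is therefore expected to give about 270 nM, with a range from 120 nM to 600 nM.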

Compound 4, half-maximal inhibitory concentration: 380 nM
The estimate for compound 4 lay 1.4-fold (0.15 log units) below the measured number; the range from low to high includes it.
By their numbers in this assay, from the lowest: compounds 3, 1, 4 and 2 (each within the scatter of the next, the first and the last beyond it).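

Notes on the 4-substituent of the phenyl ring: in this assay, the change from 4-fluorophenyl to 4-chlorophenyl gives a 1.4-fold higher number from compound 3 to compound 4 (0.15 log units; within the scatter), so these two halogens cannot be told apart at this place, and the first single-change reading at the aromatic nitrogen, a 1.3-fold higher number from compound 1 to compound 4 (0.12 log units; within the scatter), likewise does not separate hydrogen from methyl when the chloro is present. Against the unsubstituted phenyl, the chloro gives a 2.0-fold lower number from compound 2 to compound 4 (0.30 log units; within the scatter), whereas the fluoro gives a 2.8-fold lower number from compound 2 to compound 3 (0.45 log units; beyond the scatter), so in this small set only the fluoro step clears the scatter, even though fluoro and chloro themselves cannot be ordered. No supporting measurement bears on why these steps have the sizes they do.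

Still open, as far as these compounds go, is whether a group of another kind at this place, such as methoxy, an amine or a carboxylic acid, would give a step beyond the scatter from compound 3. Also open, from the compounds shown here alone, is whether the methyl on the aromatic nitrogen would read the same with fluoro on the phenyl ring instead of chloro.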